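Swapping the five-membered ring on a shared imidazoline core

The compounds below may be only part of what the source reports. "The series", "measured", "known", "first", "only" and "open" are said of these compounds alone.

Measured so far in a functional assay with Alpha-1D adrenergic receptor (Homo sapiens) as the target, read by calcium flux; on this read-out lower numbers stand for smaller maximal responses and higher numbers for larger maximal responses:
compound 1 `Cc1ccc(-c2ccccc2NCC2=NCCN2)n1C` gives 0%;
compound 2 `CCn1ccc(-c2ccccc2NCC2=NCCN2)n1` gives 0%;
compound 3 `Cn1cccc1-c1ccccc1NCC1=NCCN1` gives 32%.

Compound 3 stands highest of the three; compound 1 and compound 2 both sit at zero, each well beyond the scatter below it. Within the data shown here, the only one-place step measured is a number 32 percentage points higher from compound 1 to compound 3 (beyond the scatter), which shows that a small change on the five-membered ring can move the maximal response a long way.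

Compound 4 `Cn1cc(-c2ccccc2NCC2=NCCN2)cn1` differs from compound 3 in one place: 1-methyl-1H-pyrazol-4-yl in place of 1-methyl-1H-pyrrol-2-yl on an aromatic carbon. Among the measured compounds shown here, no measured step swaps one five-membered ring for another, so the step from compound 3 to compound 4 has no direct precedent. Compounds 1 and 2 show that two of three variants of this ring give no response at all, so a drop toward zero is the more likely outcome, and a step of about a number 20 percentage points lower from compound 3 to compound 4 (beyond the scatter) is expected in this assay. Compound 4 is therefore estimated at 12%, most likely between 0% and 40%.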

Compound 4, largest response reached (reported as maximal response), in percent of the reference or control that the assay uses: 0%
Compound 4: middle estimate off by 12 percentage points, on the high side; low and high end bracket the measured number.
By their numbers in this assay, from the lowest: compounds 1, 2 and 4 (each within the scatter of the next); then compound 3.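

In this assay, replacing 1-methyl-1H-pyrrol-2-yl with 1-methyl-1H-pyrazol-4-yl gives a number 32 percentage points lower from compound 3 to compound 4 (beyond the scatter) and removes the response seen with compound 3. The earlier step showed that one methyl on the five-membered ring can matter, whereas this one shows that changing the ring itself, at the same place on the six-membered ring, can matter just as much. Both groups have 6 heavy atoms, so that count alone does not set the response, and no measurement here explains the loss.

The change alters both the number of ring hetero atoms and the point of attachment, so their separate contributions remain unresolved. From the compounds shown here alone, a 1-methyl-1H-pyrrol-3-yl group or a plain phenyl ring at this place could help separate them, and whether either restores the response remains open.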